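Compound 4: chloro removed from the phenyl of compound 3

The source may hold more compounds than are shown below. What is called first, only, known or untested is meant among the compounds shown, and "the series" means these compounds.

Compound 1 `COc1cc(-n2cnc3ccc(-c4ccc(C(F)(F)F)cc4)cc32)cc(OC)c1OC` gives 3390 nM in a functional assay on A549 cells (Homo sapiens) for antiproliferative activity, read by MTT assay, with a stated time of 72 h; on this read-out higher numbers stand for weaker inhibition and lower numbers for stronger inhibition. Compound 2 `COc1ccc(-c2ccc3ncn(-c4cc(OC)c(OC)c(OC)c4)c3c2)cc1` reaches only the assay limit, > 10000 nM, in this assay. Compound 3 `COc1cc(-n2cnc3ccc(-c4ccccc4Cl)cc32)cc(OC)c1OC` likewise reaches only the limit > 10000 nM in this assay, so it stands at the limit of > 10000 nM in this assay, at which 2 of the 3 values shown sit, and no number is known for it. The steps of an at least 2.9-fold higher number from compound 1 to compound 2 (0.46 log units; beyond the scatter) and an at least 2.9-fold higher number from compound 1 to compound 3 (0.46 log units; beyond the scatter) both run toward weaker inhibition, while the step that the two limits leave unreadable from compound 2 to compound 3 cannot be read. Compound 4 `COc1cc(-n2cnc3ccc(-c4ccccc4)cc32)cc(OC)c1OC` differs from compound 3 by hydrogen in place of chloro on an aromatic carbon. Going by the values given here, no measured step covers this change; only an at least 2.9-fold higher number from compound 1 to compound 3 (0.46 log units; beyond the scatter) bears on the pair, and it fixes merely a floor for compound 3. Compound 4 is therefore expected to stay weak, at an estimated 9000 nM within 3000 nM to 30000 nM. That estimate means an expected step of an at least 1.1-fold lower number from compound 3 to compound 4 (0.04 log units; that floor lies within the scatter).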

Compound 4, half-maximal inhibitory concentration: 3060 nM
Beside the measured number, compound 4's estimate is 2.9-fold (0.47 log units) above it; the measured number falls inside the stated range.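

Hydrogen in place of chloro gives an at least 3.2-fold lower number from compound 3 to compound 4 (0.51 log units; beyond the scatter), and hydrogen in place of methoxy gives an at least 3.2-fold lower number from compound 2 to compound 4 (0.51 log units; beyond the scatter), so in this assay the plain phenyl keeps a measurable number that the 2-chlorophenyl and 4-methoxyphenyl compounds do not reach. Hydrogen in place of trifluoromethyl gives a 1.1-fold lower number from compound 1 to compound 4 (0.04 log units; within the scatter), so this assay does not separate the phenyl from the 4-(trifluoromethyl)phenyl, and no substituent on this ring is needed for the activity seen.

The step between compound 2 and compound 3 cannot be read, as each stands only at a limit: the limit of > 10000 nM in this assay, at which 2 of the 4 values shown sit. Going by these compounds, whether an amine or a carboxylic acid on this phenyl would shift the number remains open.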